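Swapping the chain tail of compound 1 for a triazole diol

A few compounds are considered here, and "the series" means these few. Any claim that something is new, unique, unknown or untested is made for them only; others in the source may bear on it.

Compound 1 `O=C1c2c[n+]([O-])c3ccccc3c2C(=O)c2c1c1ccccc1n2CCCCn1ccnc1` gives 240 nM in a functional assay on HCT-116 cells (Homo sapiens) for cytotoxicity, read by MTT assay, with a stated time of 72 h (on this read-out lower numbers stand for stronger inhibition and higher numbers for weaker inhibition), the higher of the two numbers measured here. Compound 2 `CN1CCN(CCCCn2c3c(c4ccccc42)C(=O)c2c[n+]([O-])c4ccccc4c2C3=O)CC1` gives 10 nM, and the step of a 24-fold lower number from compound 1 to compound 2 (1.38 log units; beyond the scatter) shows that changing the group at the far end of the chain can matter greatly. Compound 3 `O=C1c2c[n+]([O-])c3ccccc3c2C(=O)c2c1c1ccccc1n2Cc1cn(C[C@@H](O)CO)nn1` differs from compound 1 by 1-(2,3-dihydroxypropyl)-1H-1,2,3-triazol-4-yl in place of 3-(1H-imidazol-1-yl)propyl on a saturated chain carbon bound to an aromatic nitrogen. Within the data shown here, only that one step bears on this change, and it used a different group, so its direction cannot simply be carried over. For compound 3 the expected value is 150 nM, between 40 nM and 600 nM, an estimated step of a 1.6-fold lower number from compound 1 to compound 3 (0.20 log units; within the scatter).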

Compound 3, half-maximal inhibitory concentration: 190 nM
The estimate for compound 3 lay 1.3-fold (0.10 log units) below the measured number; the range from low to high includes it.
By their numbers in this assay, from the lowest: compound 2; then compounds 3 and 1 (each within the scatter of the next).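

In this assay the triazole diol tail reads level with the imidazole tail, with a 1.3-fold lower number from compound 1 to compound 3 (0.10 log units; within the scatter), so a very different tail can sit on this saturated chain carbon without moving the number beyond the scatter. The 4-methylpiperazine tail keeps its large advantage, with a 19-fold higher number from compound 2 to compound 3 (1.28 log units; beyond the scatter), so not every replacement of the imidazole gives that gain. No evidence at hand explains this difference. Going by these compounds, compound 3 changes the ring and the chain together, so the effect of each alone stays open. On these data alone, whether a morpholine or a dimethylamino group at the end of the butyl chain would match compound 2 also stays open.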